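The source may report more compounds than this note shows. Statements on the series, on what has been measured and on what is new or still open speak of the compounds shown alone.

Three compounds sharing one core were tested in a functional assay on CHO cells for antagonist activity at prostaglandin E2 receptor EP4 subtype (Mus musculus), read by calcium flux, with a stated time of 15 min; on this read-out higher numbers stand for weaker inhibition and lower numbers for stronger inhibition. Compound 1 `C[C@H](NC(=O)c1c(-c2ccccc2)nnn1CCOc1ccc(F)cc1)c1ccc(C(=O)O)cc1` gives 132 nM in this assay, compound 2 `Cc1ccc(-c2nnn(Cc3ccc(C(F)(F)F)cc3)c2C(=O)N[C@@H](C)c2ccc(C(=O)O)cc2)s1` gives 42.1 nM, and compound 3 `C/C=C/c1nnn(Cc2ccc(C(F)(F)F)cc2)c1C(=O)NCc1ccc(C(=O)O)cc1` gives 130 nM. On these numbers compound 3 and compound 1 lie within the scatter of one another, while compound 2 stands beyond the scatter at a lower number than either. Compound 4 `C/C=C/c1nnn(Cc2ccc(C(F)(F)F)cc2)c1C(=O)NCC1CCC(C(=O)O)CC1` differs from compound 3 by 4-carboxycyclohexyl in place of 4-carboxyphenyl on a saturated chain carbon bound to an amide-type nitrogen. Among the measured compounds shown here, no measured pair shows this same change, so nothing in the data fixes its size. The step from compound 3 to compound 4 is expected to be a 1.8-fold higher number from compound 3 to compound 4 (0.27 log units; within the scatter), a modest move toward a higher number, with a wide margin either way. Compound 4 is therefore estimated at 240 nM, in a range from 80 nM to 900 nM.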

Compound 4, half-maximal inhibitory concentration: 220 nM
The estimate for compound 4 lay 1.1-fold (0.04 log units) above the measured number; low and high end bracket the measured number.
By their numbers in this assay, from the lowest: compound 2; then compounds 3, 1 and 4 (each within the scatter of the next).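

In this assay, the exchange of 4-carboxyphenyl for 4-carboxycyclohexyl on a saturated chain carbon bound to an amide-type nitrogen gives (a 1.7-fold higher number from compound 3 to compound 4 (0.23 log units; within the scatter)). Among the compounds shown here, this is the first reading at this place, and it shows that a six-membered non-aromatic ring of carbon only can stand in for the aromatic one without a step beyond the scatter. Nothing at hand accounts for this result. From the compounds shown here alone, it remains open whether a primary amide or a nitrile could replace the carboxylic acid on that ring. Also open, going by these compounds, is whether the same exchange would hold on the methyl-bearing chain carbon of compound 2.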